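Propyl Enters an Aromatic Position of Compound 2

A few compounds are considered here, and "the series" means these few. Any claim that something is new, unique, unknown or untested is made for them only; others in the source may bear on it.

Measured so far, in a functional assay on ileum with histamine H1 receptor (Cavia porcellus) as the target; a higher number here means weaker binding, a lower number tighter binding:
compound 1, `O=c1oc2cc(OCCCN3CCN(Cc4ccc(Cl)cc4)CC3)ccc2c(O)c1[N+](=O)[O-]`, gives 1 nM;
compound 2, `O=c1oc2cc(OCC(O)CN3CCN(Cc4ccc(Cl)cc4)CC3)ccc2c(O)c1[N+](=O)[O-]`, gives 5.01 nM.

For the measured compounds named here, only one step connects these two compounds: a 5.0-fold higher number from compound 1 to compound 2 (0.70 log units; beyond the scatter). Going by the values given here, compound 2 therefore stands highest of the two numbers, and its only neighbour is compound 1, from which it is separated by that step.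

Compound 3, `CCCc1c(OCC(O)CN2CCN(Cc3ccc(Cl)cc3)CC2)ccc2c(O)c([N+](=O)[O-])c(=O)oc12`, has not yet been measured in this assay. It is built from compound 2 by one change: propyl in place of hydrogen on an aromatic carbon. Among the compounds with values here, the single measured step, from compound 1 to compound 2, concerns a hydroxy on the saturated chain, not the aromatic ring, so it does not bear on this change. Within the data shown here, no measured step in this set speaks to a propyl on the ring, and the propyl brings no donors or acceptors. With nothing to point either way, no step beyond the scatter is expected in this assay; the estimated step is a 1.0-fold lower number from compound 2 to compound 3 (0.00 log units; within the scatter). Compound 3 is expected to give about 5 nM, with a range from 1.5 nM to 16 nM.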

Compound 3, dissociation constant: 3.98 nM
Beside the measured number, compound 3's estimate is 1.3-fold (0.10 log units) above it, and the stated range covers the measured number.
By their numbers in this assay, from the lowest: compound 1; then compounds 3 and 2 (each within the scatter of the next).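

In this assay, propyl in place of hydrogen on an aromatic carbon gives a 1.3-fold lower number from compound 2 to compound 3 (0.10 log units; within the scatter), so compound 2 and compound 3 cannot be told apart in this measurement. For the compounds shown here, the only earlier step, a 5.0-fold higher number from compound 1 to compound 2 (0.70 log units; beyond the scatter), concerned a hydroxy on the saturated chain, so this is the first reading from the aromatic ring, and it shows that this carbon, ortho to a fused ring and ortho to a large group, can carry propyl without a step beyond the scatter. Nothing available explains this result, and one substitution cannot show how the number would respond to other groups at this carbon.

Going by these compounds, it remains open whether a carboxylic acid, an amine or a longer chain such as hexyl on the same aromatic carbon would also leave the number within the scatter of compound 2, or would shift it clearly. On these data alone, it is also open whether propyl at this carbon would give a similar result on compound 1, whose saturated chain has hydrogen in place of the hydroxy.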